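A few compounds are considered here, and "the series" means these few. Any claim that something is new, unique, unknown or untested is made for them only; others in the source may bear on it.

Measured compounds, with the half-maximal inhibitory concentration in a functional assay on A549 cells (Homo sapiens) for inhibition, read by MTT assay, with a stated time of 48 h; a lower number here means a stronger inhibitor, a higher number a weaker inhibitor:

compound 1 `Cc1ccc(-n2cc(NC(=O)c3cccc(NS(=O)(=O)c4ccccc4)c3)cn2)cc1` — 18900 nM
compound 2 `Cc1ccc(-n2cc(NC(=O)c3cccc(NS(=O)(=O)c4ccc(Cl)cc4)c3)cn2)cc1` — 15600 nM
compound 3 `Cc1ccc(-n2cc(NC(=O)c3ccc(NS(=O)(=O)c4ccccc4)cc3)cn2)cc1` — 54700 nM

Compound 1 and compound 2 share a core and differ by chloro in place of hydrogen on an aromatic carbon. In this assay this gave a 1.2-fold lower number from compound 1 to compound 2 (0.08 log units; within the scatter), so the two values cannot be told apart. Compound 3 is built from the same atoms as compound 1, joined differently; the difference between the two cores is not broken down here. Compound 3 has the highest number of the three, beyond the scatter against both compound 1 and compound 2.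

Compound 4 `Cc1ccc(-n2cc(NC(=O)c3ccc(NS(=O)(=O)c4ccc(Cl)cc4)cc3)cn2)cc1` is not yet measured. It differs from compound 3 by chloro in place of hydrogen on an aromatic carbon. The place is described in the same words as for the step from compound 1 to compound 2, so this is the same change made on the core of compound 3. The expectation for this assay is a step of a 1.2-fold lower number from compound 3 to compound 4 (0.08 log units; within the scatter), a flat step like the earlier one, because the only shown instance of the change gave a 1.2-fold lower number from compound 1 to compound 2 (0.08 log units; within the scatter). Compound 4 is therefore estimated at 45000 nM, with a range from 20000 nM to 100000 nM.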

Compound 4, half-maximal inhibitory concentration: 22000 nM
The estimate for compound 4 lay 2.0-fold (0.31 log units) above the measured number; the range from low to high includes it.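

In this assay, phenylsulfonyl to (4-chlorophenyl)sulfonyl on the core of compound 3 gave a 2.5-fold lower number from compound 3 to compound 4 (0.40 log units; beyond the scatter). Set beside the same change on the core of compound 1, the two steps cannot be told apart: the same change on two cores in this assay, a 1.2-fold lower number (0.08 log units; within the scatter) from compound 1 to compound 2 and a 2.5-fold lower number (0.40 log units; beyond the scatter) from compound 3 to compound 4, 2.1-fold (0.31 log units) apart, within the scatter of two such steps. Within the data shown here, this shows that the change carries from one core to the other without a measurable difference in the size of the step, but it rests on only two pairs, and although only the newer step lies beyond the scatter, that does not establish that the core of compound 3 responds more strongly, nor does it give a general size for the change.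

The compounds shown carry only hydrogen or chloro at this place, so the outcome with fluoro, methoxy or an amine there remains open. Also open, on these data alone, is whether a carboxylic acid or a longer chain in place of the methyl group of the shared core would alter the number in this assay.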